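Swapping the carbonyl substituent in a small series

The source may hold more compounds than are shown below. What is called first, only, known or untested is meant among the compounds shown, and "the series" means these compounds.

In an ADME assay on L6 cells (Rattus norvegicus) for cytotoxicity (a higher number here means a weaker inhibitor, a lower number a stronger inhibitor), compound 1 `O=C(Nc1c(O)cccc1-c1nc2c(C(=O)O)cccc2o1)c1cccc(Cl)c1` gives 143000 nM and compound 2 `O=C(Nc1c(O)cccc1-c1nc2c(C(=O)O)cccc2o1)c1ccc(F)c(F)c1F` gives 210000 nM, values within the scatter of each other. Compound 3 `O=C(Nc1c(O)cccc1-c1nc2c(C(=O)O)cccc2o1)c1cc2ccccc2[nH]1` is the next case, with 1H-indol-2-yl in place of 2,3,4-trifluorophenyl on a carbonyl carbon. Within the data shown here, only one measured step bears on this place, a 1.5-fold higher number from compound 1 to compound 2 (0.17 log units; within the scatter), and it stays within the scatter. On that single step, no shift beyond the scatter is expected in this assay, although no fused ring has been measured here. The expected step is a 1.3-fold lower number from compound 2 to compound 3 (0.12 log units; within the scatter). For compound 3 the estimate is 160000 nM, with an expected range of 70000 nM to 300000 nM.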

Compound 3, half-maximal inhibitory concentration: 212000 nM
Compound 3: middle estimate off by 1.3-fold (0.12 log units), on the low side, within the range that was stated.
By their numbers in this assay, from the lowest: compounds 1, 2 and 3 (each within the scatter of the next).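

In this assay the 1H-indol-2-yl group, the first fused ring on this carbonyl carbon, gives a 1.0-fold higher number from compound 2 to compound 3 (0.00 log units; within the scatter) and a 1.5-fold higher number from compound 1 to compound 3 (0.17 log units; within the scatter) and both steps lie within the scatter. At this place, then, a five-membered aromatic ring with 1 hetero atom and 1 hydrogen-bond donor enters with no shift beyond the scatter, so all three aromatic groups read alike. No measurement on hand explains this result. Still open, as far as these compounds go, is whether a group of another kind on this carbonyl carbon, such as a saturated amine or a longer alkyl chain, would move the number beyond the scatter.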